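Extending the indole nitrogen substituent toward a hydroxypropyl chain

The source may hold more compounds than are shown below. What is called first, only, known or untested is meant among the compounds shown, and "the series" means these compounds.

Of the compounds shown here, three sharing one core have been measured in a functional assay on NCI-H1975 cells (Homo sapiens) for antiproliferative activity, read by MTT assay, with a stated time of 72 h; a lower number here means a stronger inhibitor, a higher number a weaker inhibitor. Compound 1 `COc1cc(N(C)CCN(C)C)c(NC(=O)c2cccnc2)cc1Nc1nccc(-c2cn(C)c3ccccc23)n1` gives 1750 nM. Compound 2 `COc1cc(N(C)CCN(C)C)c(NC(=O)c2ccncn2)cc1Nc1nccc(-c2cn(C)c3ccccc23)n1` gives 1560 nM. Compound 3 `COc1cc(N(C)C)c(NC(=O)c2ccncn2)cc1Nc1nccc(-c2cn(C)c3ccccc23)n1` gives 1250 nM. Compound 2 stands second highest of the three numbers, but its step to compound 1 and its step to compound 3 both lie within the scatter, so the three values are not distinguishable from one another.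

Compound 4 `COc1cc(N(C)CCN(C)C)c(NC(=O)c2ccncn2)cc1Nc1nccc(-c2cn(CCCO)c3ccccc23)n1` differs from compound 2 by 2-hydroxyethyl in place of hydrogen on a saturated chain carbon bound to an aromatic nitrogen. Within the data shown here, no measured pair shows exactly this change. The closest comparison is the step of a 1.2-fold lower number from compound 2 to compound 3 (0.10 log units; within the scatter), which also alters a saturated chain carbon bound to an aromatic nitrogen and stays within the scatter. The step of a 1.1-fold lower number from compound 1 to compound 2 (0.05 log units; within the scatter) concerns the carbonyl substituent and is likewise within the scatter. On this evidence, a modest change at a chain carbon on an aromatic nitrogen has not moved the number, so no step beyond the scatter is expected in this assay in either direction. The estimated step from compound 2 to compound 4, a 1.0-fold lower number from compound 2 to compound 4 (0.02 log units; within the scatter), is expected to remain within the scatter. Compound 4 is therefore expected to give 1500 nM, with a range from 700 nM to 3200 nM.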

Compound 4, half-maximal inhibitory concentration: 2120 nM
Estimate against measurement, compound 4: 1.4-fold (0.15 log units) below, and the stated range covers the measured number.
By their numbers in this assay, from the lowest: compounds 3, 2, 1 and 4 (each within the scatter of the next).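

In this assay, among these compounds, the one direct reading at this place is a 1.4-fold higher number from compound 2 to compound 4 (0.13 log units; within the scatter), and it comes with 2-hydroxyethyl in place of hydrogen on a saturated chain carbon bound to an aromatic nitrogen. Among the compounds shown here, the earlier compounds changed only the carbonyl substituent and the side chain on the other aromatic nitrogen, so this pair is the first to show that the same number holds, within the scatter, when methyl becomes 3-hydroxypropyl. For the compounds shown here, that statement rests on this single pair and covers only this chain on the core of compound 2. Nothing available here bears on why the number behaves this way at this place.

On these data alone, it remains open whether an amine, a carboxylic acid or a longer chain at the same place would give a step beyond the scatter, or would also stay within it. Also open, as far as these compounds go, is whether 3-hydroxypropyl would read the same way alongside the pyridin-3-yl carbonyl substituent of compound 1 or the shorter side chain of compound 3.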